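Working notes: a 2,4-dichlorophenyl swap for compound 3

The source may hold more compounds than are shown below. What is called first, only, known or untested is meant among the compounds shown, and "the series" means these compounds.

Of the compounds shown here, two have been measured so far in a functional assay on HL-60 cells (Homo sapiens) for antiproliferative activity, with a stated time of 24 h; a lower number here means a stronger inhibitor, a higher number a weaker inhibitor. Compound 1 (`NC(=O)c1c(NC(=O)c2ccc(C(F)(F)F)cc2)sc2c1CCN(Cc1ccc(Cl)cc1Cl)C2`) gives 14900 nM, and compound 2 (`NC(=O)c1c(NC(=O)c2ccccc2F)sc2c1CCN(Cc1cccc(Cl)c1)C2`) gives 19800 nM. These two numbers lie within the scatter of each other, so compound 2 stands level with compound 1 on the data available, and neither can be ranked.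

Compound 3 (`NC(=O)c1c(NC(=O)c2ccccc2F)sc2c1CCN(Cc1ccc(Cl)cc1Cl)C2`) differs from compound 2 in one place: 2,4-dichlorophenyl in place of 3-chlorophenyl on a saturated chain carbon bound to an amine nitrogen in a ring. In words, 2,4-dichlorophenyl stands in place of 3-chlorophenyl on a saturated chain carbon bound to an amine nitrogen in a ring. For the measured compounds named here, no measured pair differs in one place, so the size of this change in this assay has not been observed directly. Going by the values given here, the only guide is compound 1, which carries the same 2,4-dichlorophenyl group on a different acyl part and gives 14900 nM. On that basis, only a small move towards a lower number is expected, probably no larger than the scatter. The expected step of a 1.2-fold lower number from compound 2 to compound 3 (0.09 log units; within the scatter) reflects this. For compound 3, the estimated value is 16000 nM, with an expected range of 8000 nM to 30000 nM.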

Compound 3, half-maximal inhibitory concentration: 13100 nM
The estimate for compound 3 lay 1.2-fold (0.09 log units) above the measured number; measured number inside the range.
By their numbers in this assay, from the lowest: compounds 3, 1 and 2 (each within the scatter of the next).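

In this assay the position on a saturated chain carbon bound to an amine nitrogen in a ring now has a direct pair, which reads a 1.5-fold lower number from compound 2 to compound 3 (0.18 log units; within the scatter), so 2,4-dichlorophenyl and 3-chlorophenyl cannot be told apart there with the 2-fluorophenyl acyl part in place. The acyl part also has its first direct reading, as 2-fluorophenyl in place of 4-(trifluoromethyl)phenyl on a carbonyl carbon gives a 1.1-fold lower number from compound 1 to compound 3 (0.06 log units; within the scatter), so these two groups cannot be told apart with 2,4-dichlorophenyl held constant. All three compounds therefore stand level, with neither change separating them, and no independent evidence on hand bears on this result.

Both pairs change one aryl group for another halogen-bearing aryl group, so they leave open whether an amine or a carboxylic acid on the phenyl ring, or a longer chain in place of the saturated chain carbon, would give a step beyond the scatter. For the compounds shown here, the single pair at each position also cannot show whether either reading holds with other groups elsewhere on the shared core.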